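The source may report more compounds than this note shows. Statements on the series, on what has been measured and on what is new or still open speak of the compounds shown alone.

In a functional assay on CHO cells for antagonist activity at adenosine receptor A2b (Homo sapiens), read by cAMP accumulation (a lower number here means a stronger inhibitor, a higher number a weaker inhibitor), none of the three measured compounds yields a number. Compound 1 `COc1cccc2cc(-c3ccc([N+](=O)[O-])cc3)c(=O)oc12` gives > 30000 nM, which is a limit of the assay rather than a value. Compound 2 `O=c1oc2c(O)c(O)ccc2cc1-c1ccc(O)cc1` likewise reaches only the limit > 30000 nM. Compound 3 `O=c1oc2c(O)cccc2cc1-c1ccc(O)c(O)c1` stands at > 30000 nM, again a limit. Its place among the measured compounds therefore cannot be fixed beyond the observation that all three sit at the limit of > 30000 nM in this assay, at which 3 of the 3 values shown sit. Compound 4 `O=c1oc2c(O)c(O)ccc2cc1-c1ccc(O)c(O)c1` is yet to be measured in this assay; it differs from compound 3 by hydroxy in place of hydrogen on an aromatic carbon. For the measured compounds named here, no step between measured compounds is available to guide the size of this change, and nothing in the data points in either direction. Because compound 3 reports only > 30000 nM, compound 4 is expected to remain at the limit as well, with an expected step that the limit leaves unreadable from compound 3 to compound 4 that the assay would not resolve. Compound 4 is thus estimated at 50000 nM, within a range of 15000 nM to 200000 nM.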

Compound 4, half-maximal inhibitory concentration: > 30000 nM
Compound 4: only a limit was reported; the forecaster's own chance of this, stated with the estimate: 85%; the middle value lies beyond the limit too.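

In this assay compound 4 gives > 30000 nM, which is a limit and not a number. The steps to compound 4 from compound 2 and from compound 3 cannot be read. The compounds shown leave open what an added hydroxy does to inhibition, as none yields a number: the limit of > 30000 nM in this assay, at which 4 of the 4 values shown sit.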